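Adding a Second Chloro Group to Compound 3

This account rests on a few compounds, and the source may have more. Where it says the series, first, only, none or still open, it means among the compounds named here.

Among the measured compounds shown here, compound 3 `CC(=O)OC/C(=C\c1ccc(Cl)cc1)C(=O)c1ccc(Cl)cc1` gives 5400 nM in a functional assay on T47D cells (Homo sapiens) for inhibition, read by sulforhodamine B assay, with a stated time of 48 h (a higher number here means a weaker inhibitor of growth, a lower number a stronger inhibitor of growth), the lowest of the three numbers measured so far. Compound 1 `CC(=O)OC/C(=C\c1ccc(Cl)cc1Cl)C(=O)c1ccccc1` gives 9500 nM, which lies within the scatter of compound 3, so the two cannot be ranked against each other. Compound 2 `CC(=O)OC/C(=C\C1CCCCC1)C(=O)c1ccc(Cl)cc1` gives 18000 nM. For the measured compounds named here, the only single-site step measured, a 3.3-fold lower number from compound 2 to compound 3 (0.52 log units; beyond the scatter), is modest. Compound 4 `CC(=O)OC/C(=C\c1ccc(Cl)cc1Cl)C(=O)c1ccc(Cl)cc1` differs from compound 3 by chloro in place of hydrogen on an aromatic carbon. Going by the values given here, no measured step adds a chloro group in this way, and the step between compound 2 and compound 3 alters a different part of the molecule, so it offers no direct guide. The expectation is therefore a 1.1-fold lower number from compound 3 to compound 4 (0.03 log units; within the scatter), a change not beyond the scatter. Compound 4 is estimated at 5000 nM, with a range from 2000 nM to 12000 nM.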

Compound 4, concentration for 50% growth inhibition: 5200 nM
Compound 4: middle estimate off by 1.0-fold (0.02 log units), on the low side, and the stated range covers the measured number.
By their numbers in this assay, from the lowest: compounds 4, 3, 1 and 2 (each within the scatter of the next, the first and the last beyond it).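

In this assay, going from 4-chlorophenyl to 2,4-dichlorophenyl gives a 1.0-fold lower number from compound 3 to compound 4 (0.02 log units; within the scatter), and chloro in place of hydrogen on the other aromatic ring gives a 1.8-fold lower number from compound 1 to compound 4 (0.26 log units; within the scatter), so neither added chloro group separates the compounds it connects. Among the new steps, only 2,4-dichlorophenyl in place of cyclohexyl gives a modest step beyond the scatter, a 3.5-fold lower number from compound 2 to compound 4 (0.54 log units; beyond the scatter), and this is the same kind of swap as the earlier one. Nothing available here explains these results.

As far as these compounds go, whether a methoxy group or an amine at this aromatic carbon would give a number like that of chloro remains open. So does the effect of a longer chain in place of the acetyl group.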